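Series notes: removing the ring fluorine from compound 1

The source may report more compounds than this note shows. Statements on the series, on what has been measured and on what is new or still open speak of the compounds shown alone.

Measured so far:
- compound 1 `N/C(=N\NC(=S)N1CCCC1)c1ccc(F)cn1` — 73%
- compound 2 `N/C(=N\NC(=S)N1CCOCC1)c1ccc(F)cn1` — 61.5%

In a functional assay on MCF7 cells (Homo sapiens) for cytotoxicity, read by MTT assay, with a stated time of 72 h, tested at 100 uM (on this read-out lower numbers stand for less inhibition of growth and higher numbers for more inhibition of growth at the one concentration tested), compound 1 gives 73%, the higher of the two numbers available. Going by the values given here, compound 2 gives 61.5%; the single measured step is a number 11.5 percentage points lower from compound 1 to compound 2 (beyond the scatter), for morpholin-4-yl in place of pyrrolidin-1-yl on the thiocarbonyl carbon.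

Compound 3 `N/C(=N\NC(=S)N1CCCC1)c1ccccn1` differs from compound 1 by hydrogen in place of fluoro on an aromatic carbon. Among the compounds with values here, no measured step touches the aromatic ring; the one step known concerns the thiocarbonyl amine alone, so it offers no direct guide to this change. Within the data shown here, with the shared core otherwise kept, a step of small size is expected, most likely a modest drop or none beyond the scatter, since the only observed change was itself modest, a number 11.5 percentage points lower from compound 1 to compound 2 (beyond the scatter).

Compound 3 is therefore estimated at 65%, range 45% to 82%, an expected step of a number 8 percentage points lower from compound 1 to compound 3 (within the scatter).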

Compound 3, percent growth inhibition at one concentration: 74.9%
Compound 3: middle estimate off by 9.9 percentage points, on the low side; the range from low to high includes it.
By their numbers in this assay, from the lowest: compound 2; then compounds 1 and 3 (each within the scatter of the next).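

In this assay, hydrogen in place of fluoro on the aromatic carbon para to a large group gives a number 1.9 percentage points higher from compound 1 to compound 3 (within the scatter), so at this position the fluoro can be lost with no change that the read-out separates from scatter. Going by these compounds alone, this is the first reading on the aromatic ring; the earlier step, a number 11.5 percentage points lower from compound 1 to compound 2 (beyond the scatter), concerned only the amine on the thiocarbonyl carbon, and in this small set that amine change is the only one beyond the scatter. Nothing available bears on why the ring step is so small.

From the compounds shown here alone, whether hydrogen and fluoro also match when morpholin-4-yl replaces pyrrolidin-1-yl remains open. Also open, going by these compounds, is how this aromatic carbon responds to other groups, such as chloro, methoxy or a carboxylic acid.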